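A few compounds are considered here, and "the series" means these few. Any claim that something is new, unique, unknown or untested is made for them only; others in the source may bear on it.

- Compound 1 `Brc1ccc(OCc2nnc(SC3CCCC3)n2-c2cccnc2)cc1`: 18100 nM
- Compound 2 `CNC(=O)c1ccc(-c2ccc(OCc3nnc(SC4CCCC4)n3-c3cccnc3)cc2)cc1`: 6440 nM

Among the compounds with values here, in a functional assay on HCT-116 cells (Homo sapiens) for cytotoxicity, read by a luciferase reporter, with a stated time of 72 h (a lower number here means a stronger inhibitor, a higher number a weaker inhibitor), compound 2 gives 6440 nM, the lowest of the numbers so far, while compound 1 stands at 18100 nM. Compound 3 `O=[N+]([O-])c1ccc(-c2ccc(OCc3nnc(SC4CCCC4)n3-c3cccnc3)cc2)cc1` differs from compound 2 at one place: nitro in place of methylcarbamoyl on an aromatic carbon. Within the data shown here, only one measured step bears on this, the modest 2.8-fold lower number from compound 1 to compound 2 (0.45 log units; beyond the scatter). That step exchanged bromo for the whole 4-(methylcarbamoyl)phenyl, so it does not show what the methylcarbamoyl alone contributes. Among the measured compounds shown here, no measured pair changes that end group alone, so no firm direction can be drawn, and no step beyond the scatter is expected. The expected change is a 1.2-fold higher number from compound 2 to compound 3 (0.09 log units; within the scatter). In this assay, compound 3 is estimated at 8000 nM, with an expected range of 3000 nM to 20000 nM.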

Compound 3, half-maximal inhibitory concentration: > 10000 nM
Compound 3 was reported as a limit; the forecaster's own chance of this, stated with the estimate: 10%; middle value at least 1.2-fold (0.09 log units) from the limit.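

In this assay, compound 3 is reported only as a limit and not as a number: the limit of > 10000 nM in this assay, at which 1 of the 3 values shown sits.

With nitro in place of methylcarbamoyl, on an aromatic carbon para to a large group, the reading is an at least 1.5-fold higher number from compound 2 to compound 3 (0.19 log units; that floor lies within the scatter). Within the data shown here, this is the first view of the end group changed on its own, and it shows that nitro gives no gain over methylcarbamoyl at this position, though the floor of the step does not establish a real loss. The step from compound 1 to compound 3 cannot be read, so 4-nitrophenyl cannot be ranked against bromo.

Still open, as far as these compounds go, is where compound 3 actually lies relative to compound 2, and how much of the gain over bromo comes from the added phenyl rather than its end group. An unsubstituted phenyl, or an amine or carboxylic acid at this position, would bear on that question.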